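A few compounds are considered here, and "the series" means these few. Any claim that something is new, unique, unknown or untested is made for them only; others in the source may bear on it.

Of the compounds shown here, two have been tested in a functional assay on Ehrlich cells (Mus musculus) for cytotoxicity, tested at 50 ug/mL; on this read-out higher numbers stand for a stronger effect at the one concentration tested and lower numbers for a weaker effect. Compound 1 `COc1ccc(C2C(C#N)=C(N)N(c3cc(OC)c(OC)c(OC)c3)C3=C2C(=O)CC(C)(C)C3)cc1` gives 11%. Going by the values given here, compound 2 `COc1cc(N2C(N)=C(C#N)C(c3ccc(Cl)cc3Cl)C3=C2CC(C)(C)CC3=O)cc(OC)c1OC` gives 95%, the highest of the two numbers, and the only measured step, a number 84 percentage points higher from compound 1 to compound 2 (beyond the scatter), is large and beyond the scatter. Compound 3 `COc1cc(N2C(N)=C(C#N)C(c3cccc([N+](=O)[O-])c3)C3=C2CC(C)(C)CC3=O)cc(OC)c1OC` is not yet measured in this assay. Its difference from compound 2 is 3-nitrophenyl in place of 2,4-dichlorophenyl on a saturated ring carbon. Among the compounds with values here, only the step from compound 1 to compound 2 bears on this change; it shows that exchanging the group on a saturated ring carbon of the shared core can move this assay by a large amount. Within the data shown here, no measured pair places 3-nitrophenyl against any other group, so the direction of the coming step is not fixed by the data. An intermediate outcome is expected, with the estimate for compound 3 in this assay at 50%, between 10% and 95%. This estimate corresponds to an expected step of a number 45 percentage points lower from compound 2 to compound 3 (beyond the scatter).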

Compound 3, a percentage reported as activity, at one concentration (the size of the read-out at that concentration, not a potency): 30%
Compound 3: middle estimate off by 20 percentage points, on the high side, within the range that was stated.
By their numbers in this assay, from the lowest: compound 1; then compound 3; then compound 2.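

With 3-nitrophenyl as a third group on the saturated ring carbon, this assay shows an intermediate level rather than only the two extremes seen so far: the change from 2,4-dichlorophenyl is a number 65 percentage points lower from compound 2 to compound 3 (beyond the scatter), and the change from 4-methoxyphenyl is a number 19 percentage points higher from compound 1 to compound 3 (beyond the scatter). Replacing 4-methoxyphenyl at this position therefore does not by itself bring the read-out to the level of compound 2, as the two replacements end far apart. Nothing available accounts for this order of the three groups.

Open, as far as these compounds go, is whether the high level of compound 2 depends on both chlorines or on one of them, and how an unsubstituted phenyl would rank against these three groups. Also open, from the compounds shown here alone, is whether a non-aromatic group such as cyclohexyl, or a pyridine ring, is tolerated at this carbon.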